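Working notes: methoxy in place of butyl on the chain

The source may hold more compounds than are shown below. What is called first, only, known or untested is meant among the compounds shown, and "the series" means these compounds.

Measured in an ADME assay on microsomes from liver (Mus musculus) for metabolic stability, tested at 5 uM (a lower number here means that the compound disappears faster, a higher number that the compound lasts longer), so far:
Compound 1 `CCCCCCCCNc1ccc(C(=O)O)cc1S(N)(=O)=O` gives 0.3 h
Compound 2 `CCCCCCCCNc1ccc(C(=O)O)cc1S(=O)(=O)N(C)C` gives 0.217 h

Compound 2 (0.217 h) stands within the scatter of compound 1, so the two cannot be ordered on these numbers. Next is compound 3 `COCCCCNc1ccc(C(=O)O)cc1S(=O)(=O)N(C)C`, with methoxy in place of butyl on a saturated chain carbon, four bonds along the chain from a nitrogen on an aromatic ring. Among the compounds with values here, the only measured step, a 1.4-fold lower number from compound 1 to compound 2 (0.14 log units; within the scatter), is dimethylamino in place of amino on a sulfonyl sulfur. Within the data shown here, it stays within the scatter and lies away from the chain, and no measured pair changes the chain itself. No step beyond the scatter is therefore expected in this assay, though support is thin and the range stays wide. The expected step is a 1.4-fold higher number from compound 2 to compound 3 (0.14 log units; within the scatter), with no firm direction. For compound 3 the estimated half-life is 0.3 h, with an expected range of 0.13 h to 0.8 h.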

Compound 3, half-life: > 1 h
Compound 3: only a limit was reported; the forecaster's own chance of this, stated with the estimate: 5%; at least 3.3-fold (0.52 log units) between middle value and limit.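

The change from butyl to methoxy, on a saturated chain carbon, four bonds along the chain from a nitrogen on an aromatic ring, gives an at least 4.6-fold higher number from compound 2 to compound 3 (0.66 log units; beyond the scatter) in this assay. The earlier change on the sulfonyl sulfur, a 1.4-fold lower number from compound 1 to compound 2 (0.14 log units; within the scatter), stayed within the scatter, so this chain position is the only place shown where a single change moves the half-life beyond it. For compound 3, > 1 h is a limit of the assay and not a number, so the full size of the step stays unknown: the limit of > 1 h in this assay, at which 1 of the 3 values shown sits.

The change alters both the atoms and the length of the chain, so the compounds shown do not separate the effect of the oxygen from that of shortening. From the compounds shown here alone, it also stays open how hexyl, or a hydroxyl or carboxylic acid in place of methoxy, would compare at this position.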